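Amide head-group swap on a long-chain threonine amide series

The source may hold more compounds than are shown below. What is called first, only, known or untested is meant among the compounds shown, and "the series" means these compounds.

Measured so far:
- compound 1 `CCCCCCCCCCCCCCCCCCNC(=O)[C@@H](NC(=O)c1cccs1)[C@@H](C)O` gives 200000 nM in a functional assay on SW-620 cells (Homo sapiens) for cytotoxicity, read by MTT assay, with a stated time of 48 h; a lower number here means a stronger inhibitor, a higher number a weaker inhibitor
- compound 2 `CCCCCCCCCCCCCCCCCCNC(=O)[C@@H](NC(=O)c1nccc2ccccc12)[C@@H](C)O` gives 136000 nM in this assay
- compound 3 `CCCCCCCCCCCCCCCCCCNC(=O)[C@@H](NC(=O)c1cc2ccccc2n1C)[C@@H](C)O` gives 124000 nM in this assay

All three compounds share the same core and differ only in the aromatic group on the carbonyl carbon. Compound 3 has the lowest number of the three, but its steps to the others are small: a 1.1-fold lower number from compound 2 to compound 3 (0.04 log units; within the scatter) and a 1.6-fold lower number from compound 1 to compound 3 (0.21 log units; within the scatter). The change from the thiophene to the isoquinoline is likewise small, a 1.5-fold lower number from compound 1 to compound 2 (0.17 log units; within the scatter). No head-group swap in this set has moved the number beyond the scatter.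

Compound 4 `CCCCCCCCCCCCCCCCCCNC(=O)[C@@H](NC(=O)/C=C/c1ccccc1)[C@@H](C)O` carries the next swap on that same carbonyl carbon: 2-phenylethenyl in place of 1-methyl-1H-indol-2-yl on a carbonyl carbon. The three measured steps all bear on it as head-group swaps at the same place, and each stayed within the scatter, so the expectation is again no step beyond the scatter in this assay, in either direction: a 1.2-fold higher number from compound 3 to compound 4 (0.08 log units; within the scatter). The entering group has no ring fused to a second ring and no hydrogen-bond acceptor, which the measured set does not cover, so the range is kept wide. Compound 4 is estimated at 150000 nM, within 60000 nM to 350000 nM.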

Compound 4, half-maximal inhibitory concentration: 200000 nM
The estimate for compound 4 lay 1.3-fold (0.12 log units) below the measured number; measured number inside the range.
By their numbers in this assay, from the lowest: compounds 3, 2, 1 and 4 (each within the scatter of the next).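

With 2-phenylethenyl on the carbonyl carbon, the head group keeps one six-membered aromatic ring, gains a double bond outside aromatic rings and has no hydrogen-bond acceptor, yet this assay shows a 1.6-fold higher number from compound 3 to compound 4 (0.21 log units; within the scatter) and a 1.5-fold higher number from compound 2 to compound 4 (0.17 log units; within the scatter) and no change at the digits printed from compound 1 to compound 4 (within the scatter) with no step beyond the scatter. This extends the flat picture at this position to a head group without a second fused ring, without nitrogen and with an open double bond, so neither the fused aromatic rings of 1-methyl-1H-indol-2-yl nor its nitrogen is required for a number in this range. No measurement among these compounds gives a reason for this lack of response to the swap.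

Going by these compounds alone, still open is whether a head group of another kind, such as an aliphatic amine or a carboxylic acid on the carbonyl carbon, would give the first step beyond the scatter. The compounds shown also leave open how far the number depends on the long chain and the free hydroxyl group of the shared core, since neither varies here, so a shorter chain remains an untested comparison in this series.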